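The source may hold more compounds than are shown below. What is called first, only, known or untested is meant among the compounds shown, and "the series" means these compounds.

Measured so far in a functional assay on MCF7 cells (Homo sapiens) for antiproliferative activity, read by sulforhodamine B assay, with a stated time of 48 h; on this read-out lower numbers stand for stronger inhibition and higher numbers for weaker inhibition:
compound 1 `C[C@@]12CCCC[C@H]1CC=C(O)C2=O` gives 119000 nM
compound 2 `C[C@H]1N=C2C[C@H]3C[C@H](C3(C)C)[C@@]2(C)OC1=O` gives 38000 nM
compound 3 `CC1(C)[C@@H]2CC3=NCC(=O)O[C@@]3(C)[C@H]1C2` gives 22000 nM

On these three numbers compound 2 stands second highest. Its nearest neighbour is compound 3, whose number is lower but within the usual scatter, so no order between these two is claimed. Compound 1 stands furthest from compound 2, with a higher number beyond the scatter. Compound 4 `CC(C)(C)OC(=O)CC[C@H]1N=C2C[C@H]3C[C@H](C3(C)C)[C@@]2(C)OC1=O` has not yet been measured; it differs from compound 2 by (tert-butoxycarbonyl)methyl in place of hydrogen on a saturated chain carbon bound to a saturated ring carbon. Within the data shown here, no pair of measured compounds shows a change of this kind, so there is no earlier step to lean on. The expected step from compound 2 to compound 4 in this assay is a 1.3-fold lower number from compound 2 to compound 4 (0.10 log units; within the scatter), and no direction beyond the scatter is expected. Compound 4 is estimated at 30000 nM, with a range from 8000 nM to 110000 nM.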

Compound 4, half-maximal inhibitory concentration: 54000 nM
The estimate for compound 4 lay 1.8-fold (0.26 log units) below the measured number; the measured number falls inside the stated range.
By their numbers in this assay, from the lowest: compounds 3, 2 and 4 (each within the scatter of the next, the first and the last beyond it); then compound 1.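

In this assay, among these compounds, the first step at this position is now available: (tert-butoxycarbonyl)methyl in place of hydrogen on a saturated chain carbon bound to a saturated ring carbon gives a 1.4-fold higher number from compound 2 to compound 4 (0.15 log units; within the scatter). The position therefore carries this sizeable group with no change beyond the scatter. No measurement shown accounts for this result.

From the compounds shown here alone, whether a carboxylic acid, an amine or a longer chain at the same place would keep the number within the scatter remains open. So does whether the same change would read alike on the core of compound 3.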